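The source may hold more compounds than are shown below. What is called first, only, known or untested is meant among the compounds shown, and "the series" means these compounds.

Working notes on the series. The shared core is that of compound 1 `C=CCn1c(=O)/c(=C\c2cccc(Cl)c2)[nH]c(=O)/c1=C\c1ccccc1OC`. In a functional assay on A549 cells (Homo sapiens) for cytotoxicity, read by CCK-8 assay, with a stated time of 72 h (a higher number here means a weaker inhibitor, a lower number a stronger inhibitor), compound 1 gives 5200 nM. Among the measured compounds shown here, compound 2 `COc1ccccc1/C=c1/[nH]c(=O)/c(=C\c2ccccc2OC)n(C)c1=O` gives 7000 nM in this assay, a number within the usual scatter of the one for compound 1, so the two cannot be ordered. Compound 3 `COc1ccccc1/C=c1/[nH]c(=O)/c(=C\c2cccc(Cl)c2Cl)[nH]c1=O` is reported as "not active" (no number reported) in this assay, with no number. For the measured compounds named here, no step between two measured compounds that differ in one place is available. Compound 4 `C=CCn1c(=O)/c(=C\c2cccc(F)c2)[nH]c(=O)/c1=C\c1ccccc1OC` differs from compound 1 by fluoro in place of chloro on an aromatic carbon. With nothing measured for such an exchange here, the step of a 1.5-fold higher number from compound 1 to compound 4 (0.19 log units; within the scatter) is expected to be small, at most just beyond the scatter, toward a somewhat higher number. Compound 4 is expected to give 8000 nM in this assay, with a range from 3000 nM to 25000 nM.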

Compound 4, half-maximal inhibitory concentration: 19700 nM
Compound 4: middle estimate off by 2.5-fold (0.39 log units), on the low side; measured number inside the range.
By their numbers in this assay, from the lowest: compounds 1 and 2 (each within the scatter of the next); then compound 4.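

Among the compounds shown here, on the aromatic carbon carrying the halogen, the change from 3-chlorophenyl to 3-fluorophenyl gives a 3.8-fold higher number from compound 1 to compound 4 (0.58 log units; beyond the scatter) in this assay as the first one-place step. This position therefore responds to the identity of the halogen, and in this single pair chloro gives the lower number. No measurement at hand accounts for the difference.

Still open, on these data alone, is how a bromo or an amino group at this place would read. As far as these compounds go, it is also open whether the same exchange gives a similar step with a methyl group in place of the allyl group on the shared core.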